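Nitro on the aromatic ring of compound 3

The source may report more compounds than this note shows. Statements on the series, on what has been measured and on what is new or still open speak of the compounds shown alone.

Measured so far in a functional assay on HCT-116 cells (Homo sapiens) for cytotoxicity, read by MTT assay, with a stated time of 72 h (on this read-out higher numbers stand for weaker inhibition and lower numbers for stronger inhibition), for the three compounds:
compound 1 `[O-][S+](CCCCN=C=S)C1CCCC1` gives 3140 nM
compound 2 `[O-][S+](CCCCN=C=S)c1ccccc1` gives 4530 nM
compound 3 `[O-][S+](CCCCN=C=S)Cc1ccccc1` gives 3660 nM

Compound 3 at 3660 nM holds the middle number of the three, yet it lies within the scatter of both other compounds, so the series shows no real separation so far. The next compound is compound 4 `O=[N+]([O-])c1ccc(C[S+]([O-])CCCCN=C=S)cc1` which carries nitro in place of hydrogen on an aromatic carbon, para to a large group, as counted here: nitro in place of hydrogen on an aromatic carbon and not yet measured. Going by the values given here, no measured pair differs in one place, so the data offer no direct guide to this kind of change and no firm direction. The expectation rests on compound 3 at 3660 nM as the starting point, and on compounds 1 and 2 staying within the scatter of it. The estimated step of a 1.2-fold lower number from compound 3 to compound 4 (0.09 log units; within the scatter) is expected to stay within the scatter in this assay as well. Compound 4 is estimated at 3000 nM with 1300 nM to 6500 nM as the expected range.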

Compound 4, half-maximal inhibitory concentration: 2830 nM
Compound 4: the middle estimate sits 1.1-fold (0.03 log units) above what was measured; low and high end bracket the measured number.
By their numbers in this assay, from the lowest: compounds 4, 1, 3 and 2 (each within the scatter of the next).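

In this assay the series now has its first pair that differs in one place, and the step (a 1.3-fold lower number from compound 3 to compound 4 (0.11 log units; within the scatter)) stays within the scatter. Nitro in place of hydrogen on an aromatic carbon, para to a large group, therefore adds 3 heavy atoms at this position without separating the two compounds on this read-out. Nothing measured here bears on why the result falls this way.

On these data alone, whether an amine or a carboxylic acid at this same place would also stay within the scatter remains open, as does the result of a longer chain in the shared core. With one readable step, no trend for substitution on this ring can be stated yet.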